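This account rests on a few compounds, and the source may have more. Where it says the series, first, only, none or still open, it means among the compounds named here.

Values in a functional assay on HCT-116 cells (Homo sapiens) for antiproliferative activity, read by MTT assay, with a stated time of 72 h; a lower number here means a stronger inhibitor, a higher number a weaker inhibitor:
Compound 1 `C=CC(=O)Nc1nc(-c2ccccc2)cs1`: 18600 nM
Compound 2 `C=CC(=O)N(CC(=O)OCC)c1nc(-c2ccccc2)cs1`: > 30000 nM (a limit)

Compound 2 has only a limit and no number: the limit of > 30000 nM in this assay, at which 1 of the 2 values shown sits. Compound 3 `C=CC(=O)N(CC(=O)OC)c1nc(-c2ccccc2)cs1` turns its ethoxycarbonyl into methoxycarbonyl: hydrogen in place of methyl on a saturated chain carbon bound to an oxygen next to a carbonyl group. Among the measured compounds shown here, the sole measured step, an at least 1.6-fold higher number from compound 1 to compound 2 (0.20 log units; that floor lies within the scatter), added the ester-bearing group to the amide-type nitrogen and bears on this change only loosely. No shift beyond the scatter is expected in this assay. The estimated step that the limit leaves unreadable from compound 2 to compound 3 remains within that scatter. Compound 3 is expected at 32000 nM, with an estimated range of 14000 nM to 70000 nM.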

Compound 3, half-maximal inhibitory concentration: > 30000 nM
Compound 3: only a limit was reported (the forecaster's own chance of this, stated with the estimate: 60%); the middle value is on the limit's open side.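

In this assay, compound 3 also gives only a limit, so shortening ethoxycarbonyl to methoxycarbonyl yields no readable value: the limit of > 30000 nM in this assay, at which 2 of the 3 values shown sit.

The step between the two esters cannot be read. Placing (methoxycarbonyl)methyl on the amide-type nitrogen gives an at least 1.6-fold higher number from compound 1 to compound 3 (0.20 log units; that floor lies within the scatter), so a real loss against the amide hydrogen is not established.

From the compounds shown here alone, whether a carboxylic acid in place of the ester, or an amine on that chain, would give a value short of the limit stays open. Any order between compound 2 and compound 3 also stays open.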